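Carboxypyridinyl replaces difluoropyridinyl on the shared core

A few compounds are considered here, and "the series" means these few. Any claim that something is new, unique, unknown or untested is made for them only; others in the source may bear on it.

Compound 1 `COc1ccc(Nc2cc3[nH]c(-c4cccc(C(F)(F)F)c4)nc3cn2)nc1`: in a physicochemical assay for solubility, using the shake flask method, in phosphate buffer, measured as kinetic solubility, with a stated time of 20 h, at pH 6.5 (a higher number here means a more soluble compound, a lower number a less soluble compound), compound 1 gives < 5000 nM, a limit of the assay.
Compound 2 `Fc1cnc(Nc2cc3[nH]c(-c4cccc(C(F)(F)F)c4)nc3cn2)c(F)c1`: in this assay compound 2 gives < 5000 nM, again a limit.

Compound 2 thus stands only at a limit, and both values shown sit there (the limit of < 5000 nM in this assay, at which 2 of the 2 values shown sit). Going by the values given here, the one measured step, a step that the two limits leave unreadable from compound 1 to compound 2, is unreadable from the two limits. Compound 3 `O=C(O)c1ccnc(Nc2cc3[nH]c(-c4cccc(C(F)(F)F)c4)nc3cn2)c1` differs from compound 2 by 4-carboxypyridin-2-yl in place of 3,5-difluoropyridin-2-yl on a nitrogen on an aromatic ring. Among the compounds with values here, no measured step bears on this change, so the size and direction in this assay cannot be read from the data; the estimate for compound 3 rests on the change alone and is expected to be 30000 nM, within 3000 nM to 300000 nM. The step of an at least 6.0-fold higher number from compound 2 to compound 3 (0.77 log units; beyond the scatter) is the expected consequence.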

Compound 3, solubility: < 5000 nM
Compound 3: a limit, no number (the forecaster's own chance of this, stated with the estimate: 25%); at least 6.0-fold (0.77 log units) between middle value and limit.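

No step among compound 1, compound 2 and compound 3 can be read in this assay, as all three sit at the same limit: the limit of < 5000 nM in this assay, at which 3 of the 3 values shown sit.

From the compounds shown here alone, whether 5-methoxypyridin-2-yl, 3,5-difluoropyridin-2-yl and 4-carboxypyridin-2-yl differ at all in solubility on the shared core stays open.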